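This account rests on a few compounds, and the source may have more. Where it says the series, first, only, none or still open, it means among the compounds named here.

Compound 1 `Cc1ccc(OCc2cn(-c3ccc(S(=O)(=O)N4CCc5ccccc5C4)cc3)nn2)cc1`: in an ADME assay on Vero cells (Chlorocebus sabaeus) for cytotoxicity, with a stated time of 4 days (a lower number here means a stronger inhibitor, a higher number a weaker inhibitor), compound 1 gives > 50 ug/mL, which is a limit of the assay and not a number.
Compound 2 `COc1cc2c(cc1OC)CN(S(=O)(=O)c1ccc(-n3cc(COc4ccc5ccccc5c4)nn3)cc1)CC2`: in this assay compound 2 gives > 50 ug/mL, again a limit of the assay.
Compound 3 `O=Cc1ccc(OCc2cn(-c3ccc(S(=O)(=O)N4CCc5ccccc5C4)cc3)nn2)cc1`: in this assay compound 3 gives > 50 ug/mL, also a limit of the assay.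

All three measured compounds share one core and differ only in the group carried on an oxygen on a saturated carbon. Each of them sits at the limit of > 50 ug/mL in this assay, at which 3 of the 3 values shown sit, so none of them yields a number within the tested range. Within the data shown here, the single step between measured compounds that differ in one place, a step that the two limits leave unreadable from compound 1 to compound 3, cannot be read in size for that reason. Compound 2 stands at that limit as well, with no number to place it relative to the others.

Compound 4 `COc1cc2c(cc1OC)CN(S(=O)(=O)c1ccc(-n3cc(COc4cc(C=O)ccc4OC)nn3)cc1)CC2` is compound 2 with 5-formyl-2-methoxyphenyl in place of naphthalen-2-yl on an oxygen on a saturated carbon. Among the measured compounds shown here, the only comparable step, a swap of a group on an aromatic ring, left both compounds at the limit, so no step beyond the scatter is expected in this assay. Compound 4 is thus expected to give 60 ug/mL, most likely as another limit, with a range from 30 ug/mL to 150 ug/mL, an expected step that the limit leaves unreadable from compound 2 to compound 4.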

Compound 4, half-maximal inhibitory concentration: > 50 ug/mL
Compound 4 gave a limit, no number; the forecaster's own chance of this, stated with the estimate: 85%; the middle value does not contradict the limit.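

Compound 2 and compound 4 both sit at a limit of the assay and not at a number, so the step between them cannot be read in size: the limit of > 50 ug/mL in this assay, at which 4 of the 4 values shown sit.

The compounds shown leave open whether the groups exchanged among them differ at all in this assay, with no compound giving a number within the tested range.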